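Swapping the aryl group on the triazole: compound 3

The compounds below may be only part of what the source reports. "The series", "measured", "known", "first", "only" and "open" are said of these compounds alone.

Measured so far:
Compound 1 `Cc1ccccc1-n1cc(-c2cccc(NS(=O)(=O)c3c[nH]c(=O)[nH]c3=O)c2)nn1` gives 9570 nM in a functional assay on HepG2 cells (Homo sapiens) for antiproliferative activity, read by MTT assay, with a stated time of 24 h; a higher number here means a weaker inhibitor, a lower number a stronger inhibitor.
Compound 2 `O=c1[nH]cc(S(=O)(=O)Nc2cccc(-c3cn(-c4ccccc4F)nn3)c2)c(=O)[nH]1` gives 13900 nM in this assay.

Both compounds share the same core and differ only in the aryl ring carried on the five-membered aromatic ring with 3 nitrogen. For the measured compounds named here, the one step measured so far, a 1.5-fold higher number from compound 1 to compound 2 (0.16 log units; within the scatter), shows that exchanging a methyl for a fluoro on that aryl ring left the result where it was. Compound 2 holds the higher of the two numbers in this assay, yet its gap to compound 1 is within the scatter, so the two cannot be ranked.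

Compound 3 `O=c1[nH]cc(S(=O)(=O)Nc2cccc(-c3cn(-c4cccc(Cl)c4)nn3)c2)c(=O)[nH]1` has not been measured in this assay. Its change from compound 2 is 3-chlorophenyl in place of 2-fluorophenyl on an aromatic nitrogen. Going by the values given here, this is again a change confined to the aryl ring on the triazole, and the only step that bears on it, a 1.5-fold higher number from compound 1 to compound 2 (0.16 log units; within the scatter), stayed within the scatter. On this basis no step beyond the scatter is expected for compound 3, in either direction.

The estimate for compound 3 in this assay is therefore 12000 nM, with a range from 5000 nM to 30000 nM. This estimate means an expected step of a 1.2-fold lower number from compound 2 to compound 3 (0.06 log units; within the scatter).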

Compound 3, half-maximal inhibitory concentration: 4200 nM
For compound 3 the middle estimate is 2.9-fold (0.46 log units) above the measured one; the measured number lies below the stated range.
By their numbers in this assay, from the lowest: compound 3; then compounds 1 and 2 (each within the scatter of the next).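

For the compounds shown here, the aryl group on the aromatic nitrogen of the five-membered ring can shift the result in this assay after all: 3-chlorophenyl in place of 2-fluorophenyl gives a 3.3-fold lower number from compound 2 to compound 3 (0.52 log units; beyond the scatter), the first change in this short series to clear the scatter. The same holds against the 2-methylphenyl group, with a 2.3-fold lower number from compound 1 to compound 3 (0.36 log units; beyond the scatter), so compound 3 is the strongest inhibitor of the three, although both steps are modest. Nothing measured here explains the gain, and no supporting data bear on it.

Compound 3 differs from compounds 1 and 2 in two ways at once, the identity of the substituent and its place on the phenyl ring, so these compounds cannot show whether the chlorine, its place or both account for the lower number. Going by these compounds, a 2-chlorophenyl or 3-fluorophenyl group on this nitrogen would separate the two, and it remains open how a ring carrying an amine or a carboxylic acid in that place would read in this assay.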